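Title: From pyridin-4-yl to pyridin-2-yl on a shared core

The source may report more compounds than this note shows. Statements on the series, on what has been measured and on what is new or still open speak of the compounds shown alone.

Compound 2, `c1cc(Nc2nccc(-c3ccncc3)n2)cc(OCCn2ccnc2)c1`, gives 200 nM in a functional assay for inhibition, with Homo sapiens as the target (on this read-out lower numbers stand for stronger inhibition and higher numbers for weaker inhibition), the lowest of the three numbers measured. Among the measured compounds shown here, its nearest neighbour is compound 1, `COc1cccc(Nc2nccc(-c3ccncc3)n2)c1`, which gives 400 nM; the one step recorded, a 2.0-fold lower number from compound 1 to compound 2 (0.30 log units; within the scatter), is within the scatter. Furthest away is compound 3, `NS(=O)(=O)c1ccc(Nc2nccc(-c3ccccn3)n2)cc1`, which gives 4600 nM, beyond the scatter from compound 2.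

Compound 4, `c1ccc(-c2ccnc(Nc3cccc(OCCn4ccnc4)c3)n2)nc1`, differs from compound 2 by pyridin-2-yl in place of pyridin-4-yl on an aromatic carbon. For the measured compounds named here, no measured step isolates this change. Going by the values given here, compound 3 is the only measured compound carrying pyridin-2-yl, but it also carries a sulfonamide in place of the ether side chain, so its weak value of 4600 nM cannot be attributed to the pyridin-2-yl group alone; the sulfonamide compound has no pyridin-4-yl partner. The expectation for this assay therefore rests on a single indirect comparison: a loss is possible, its size uncertain.

Compound 4 is estimated to give 1000 nM in this assay, within a range of 300 nM to 4000 nM. This estimate corresponds to an expected step of a 5.0-fold higher number from compound 2 to compound 4 (0.70 log units; beyond the scatter), a weakening that stays short of the value seen for compound 3.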

Compound 4, half-maximal inhibitory concentration: 400 nM
The estimate for compound 4 lay 2.5-fold (0.40 log units) above the measured number, and the stated range covers the measured number.
By their numbers in this assay, from the lowest: compounds 2, 1 and 4 (each within the scatter of the next); then compound 3.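

Among the compounds shown here, the pair of compound 2 and compound 4 is the first to isolate pyridin-2-yl in place of pyridin-4-yl on an aromatic carbon, with the ether side chain bearing the imidazole held constant. In this assay, the change gives a 2.0-fold higher number from compound 2 to compound 4 (0.30 log units; within the scatter), so the two pyridinyl groups cannot be told apart on this read-out with that side chain in place. For the compounds shown here, the earlier compounds could not show this, since the only pyridin-2-yl compound among them, compound 3, also carries a sulfonamide in place of the ether side chain, and the new pair now shows that pyridin-2-yl can sit at this position on the shared core without a step beyond the scatter. No measurement at hand offers an explanation of why the two groups read alike.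

The compounds shown leave open whether pyridin-3-yl or a plain phenyl ring would read the same at this position. They also leave open whether the match between the two pyridinyl groups holds with other side chains, such as the sulfonamide of compound 3, at 4600 nM, or a longer chain ending in an amine.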